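The source may report more compounds than this note shows. Statements on the series, on what has been measured and on what is new or still open speak of the compounds shown alone.

Measured so far:
compound 1, `O=S1(=O)C=C(Sc2nnc(-c3cccnc3)o2)c2ccccc21`: 4000 nM
compound 2, `O=S1(=O)C=C(Sc2nnc(-c3ccc(Cl)cc3)o2)c2ccccc21`: 3000 nM
compound 3, `O=S1(=O)C=C(Sc2nnc(C3CCCCC3)o2)c2ccccc21`: 3000 nM

In an ADME assay on HEK293 cells (Homo sapiens) for cytotoxicity, read by fluorescence and resazurin assay, with a stated time of 24 h (a higher number here means that more compound is tolerated, a lower number that less compound is tolerated), compound 1 gives the highest of the three numbers, but a 1.3-fold lower number from compound 1 to compound 2 (0.12 log units; within the scatter) and a 1.3-fold lower number from compound 1 to compound 3 (0.12 log units; within the scatter) both lie within the scatter, as does no change at the digits printed from compound 2 to compound 3 (within the scatter), so the three measured compounds cannot be told apart. Compound 4 `O=S1(=O)C=C(Sc2nnc(-c3cccc(Cl)c3)o2)c2ccccc21` is the unmeasured one; it differs from compound 1 in one place: 3-chlorophenyl in place of pyridin-3-yl on an aromatic carbon. For the measured compounds named here, the steps that bear on this are the swaps of the same ring in compound 1 for other rings, which gave a 1.3-fold lower number from compound 1 to compound 2 (0.12 log units; within the scatter) and a 1.3-fold lower number from compound 1 to compound 3 (0.12 log units; within the scatter); both were within the scatter, so no step beyond the scatter in this assay is expected here either. Compound 4 is therefore estimated at 3500 nM, with a range from 1800 nM to 7000 nM, which means an expected 1.1-fold lower number from compound 1 to compound 4 (0.06 log units; within the scatter).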

Compound 4, half-maximal cytotoxic concentration: 6000 nM
Compound 4: the middle estimate sits 1.7-fold (0.23 log units) below what was measured; measured number inside the range.
By their numbers in this assay, from the lowest: compounds 2, 3, 1 and 4 (each within the scatter of the next).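

Placing 3-chlorophenyl at this position still gives no step beyond the scatter in this assay, whichever group it replaces: pyridin-3-yl (a 1.5-fold higher number from compound 1 to compound 4 (0.18 log units; within the scatter)), cyclohexyl (a 2.0-fold higher number from compound 3 to compound 4 (0.30 log units; within the scatter)) or 4-chlorophenyl (a 2.0-fold higher number from compound 2 to compound 4 (0.30 log units; within the scatter)). The last step is the new comparison, and it shows that 3-chlorophenyl and 4-chlorophenyl cannot be told apart here. No measurement at hand accounts for these numbers. As far as these compounds go, whether an amine, a carboxylic acid or a longer chain at this position would give a step beyond the scatter remains open.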